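The source may report more compounds than this note shows. Statements on the series, on what has been measured and on what is new or still open speak of the compounds shown alone.

Measured so far:
Compound 1 `CCO[C@H]1C[C@@H](c2coc3ccc(F)cc3c2=O)N(c2ccccc2)O1` gives in a functional assay on Caco-2 cells (Homo sapiens) for inhibition, read by sulforhodamine B assay, with a stated time of 48 h (a higher number here means a weaker inhibitor, a lower number a stronger inhibitor), only a limit of the assay, > 60000 nM.
Compound 2 `O=C1[C@H]2[C@H](ON(c3ccccc3)[C@@H]2c2coc3ccc(F)cc3c2=O)C(=O)N1c1ccccc1` gives in this assay likewise only a limit of the assay, > 60000 nM.
Compound 3 `CCO[C@H]1C[C@@H](c2coc3ccc(C)cc3c2=O)N(c2ccccc2)O1` gives in this assay 31000 nM.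

Compound 4 `Cc1ccc2occ([C@@H]3[C@H]4C(=O)N(c5ccccc5)C(=O)[C@H]4ON3c3ccccc3)c(=O)c2c1` has not yet been measured. From compound 1 to compound 3 the change is methyl in place of fluoro on an aromatic carbon, and it made an at least 1.9-fold lower number from compound 1 to compound 3 (0.28 log units; that floor lies within the scatter). Compound 4 stands to compound 2 as compound 3 stands to compound 1: methyl in place of fluoro on an aromatic carbon, the same change at the same place. How the core of compound 2 differs from the core of compound 1 is not broken down here. Compound 2 sits at the limit of > 60000 nM in this assay, at which 2 of the 3 values shown sit. In this assay the expected step is a step that the limit leaves unreadable from compound 2 to compound 4. That expectation rests on an at least 1.9-fold lower number from compound 1 to compound 3 (0.28 log units; that floor lies within the scatter), a step within the scatter. Compound 4 is expected to give about 70000 nM. The estimate for compound 4 spans 30000 nM to 150000 nM, with a good chance that only a limit is reported again.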

Compound 4, half-maximal inhibitory concentration: > 60000 nM
Compound 4 ended at the assay's limit; the forecaster's own chance of this, stated with the estimate: 65%; the middle value is on the limit's open side.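

Compound 2 and compound 4 both give only a limit of the assay, so no step between them can be read: the limit of > 60000 nM in this assay, at which 3 of the 4 values shown sit.

From the compounds shown here alone, whether methyl in place of fluoro changes anything on the core of compound 2 stays open.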